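Compound 4: will a new ring shift clearance?

The source may hold more compounds than are shown below. What is called first, only, known or untested is meant among the compounds shown, and "the series" means these compounds.

Measured in an ADME assay on microsomes from liver (Mus musculus) for metabolic stability, read by LC-MS, using NADPH, with stated times of 10 min and 30 min, tested at 1 uM; on this read-out lower numbers stand for slow clearance and higher numbers for fast clearance:
- compound 1 `COC(=O)C1=C(CN2CCCCC2)NC(c2nccs2)=NC1(C)c1ccc(F)cc1`: 88 mL/min/kg
- compound 2 `COC(=O)C1=C(CN2CCC(F)(F)CC2)NC(c2nccs2)=NC1(C)c1ccc(F)cc1`: 88 mL/min/kg
- compound 3 `COC(=O)C1=C(CN2CCC(C(F)(F)F)C2)NC(c2nccs2)=NC1(C)c1ccc(F)cc1`: 88 mL/min/kg

Compound 3 gives 88 mL/min/kg and so stands level with compound 1 and compound 2, with no gap among the three. The unmeasured compound 4 `COC(=O)C1=C(CN2CC(OC)C2)NC(c2nccs2)=NC1(C)c1ccc(F)cc1` keeps the shared core and has 3-methoxyazetidin-1-yl in place of 3-(trifluoromethyl)pyrrolidin-1-yl on a saturated chain carbon bound to a double-bonded ring carbon. The counted change is 3-methoxyazetidin-1-yl in place of 3-(trifluoromethyl)pyrrolidin-1-yl on a saturated chain carbon bound to a double-bonded ring carbon and nothing else differs.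

Three measured steps at this same place bear on it: no change at the digits printed from compound 1 to compound 2 (within the scatter) and no change at the digits printed from compound 1 to compound 3 (within the scatter) and no change at the digits printed from compound 2 to compound 3 (within the scatter) all left the number where it was. None of these compounds carries a four-membered ring or an oxygen in this group, so the guidance is limited. The expected step, no larger than the scatter and slightly downward if anything, is a 1.1-fold lower number from compound 3 to compound 4 (0.05 log units; within the scatter) in this assay on this reasoning. For compound 4 the estimate is 78 mL/min/kg with an expected range of 45 mL/min/kg to 92 mL/min/kg as the likely span.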

Compound 4, clearance: 88 mL/min/kg
Compound 4: middle estimate off by 1.1-fold (0.05 log units), on the low side, within the range that was stated.
By their numbers in this assay, from the lowest: compounds 1, 2, 3 and 4 (each within the scatter of the next).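

In this assay, among the compounds shown here, the four-membered 3-methoxyazetidin-1-yl, the only group here that carries an oxygen, gives no change at the digits printed from compound 3 to compound 4 (within the scatter), and likewise no change at the digits printed from compound 2 to compound 4 (within the scatter) and no change at the digits printed from compound 1 to compound 4 (within the scatter). The earlier compounds varied this group only among fluorinated and plain rings without oxygen, whereas these steps show that a smaller ring with an ether oxygen, with 6 heavy atoms in place of 9, also leaves the number where it was, and no compound shown goes against this. Nothing available bears on why this position leaves the number unmoved. Still open, as far as these compounds go, is whether an open-chain group such as dimethylamino, or a carboxylic acid on the ring, would move the number at this place. Also open, from the compounds shown here alone, is whether a change elsewhere on the shared core, such as at the methyl ester, would shift clearance.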